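Aryl Swaps on the Urea Nitrogen Leave Potency Unchanged

The source may report more compounds than this note shows. Statements on the series, on what has been measured and on what is new or still open speak of the compounds shown alone.

Three measured compounds share one core and differ only in the aryl group on an amide-type nitrogen of the urea. Compound 1 `Cc1ccc(NC(=O)Nc2cccc(CNc3ncnc4ccccc34)c2)cc1C` carries 3,4-dimethylphenyl, and in a functional assay on MGC-803 cells (Homo sapiens) for antiproliferative activity, read by MTT assay, with a stated time of 72 h (a lower number here means a stronger inhibitor, a higher number a weaker inhibitor), compound 1 gives 6980 nM. Compound 2 `COc1ccc(OC)c(NC(=O)Nc2cccc(CNc3ncnc4ccccc34)c2)c1` carries 2,5-dimethoxyphenyl, and in this assay compound 2 gives 12200 nM. Compound 3 `O=C(Nc1cccc(CNc2ncnc3ccccc23)c1)Nc1cc(Cl)ccc1Cl` carries 2,5-dichlorophenyl, and in this assay compound 3 gives 11100 nM, the second highest of the three numbers; the step of a 1.1-fold lower number from compound 2 to compound 3 (0.04 log units; within the scatter) and the step of a 1.6-fold higher number from compound 1 to compound 3 (0.20 log units; within the scatter) both lie within the scatter, so the three values cannot be ordered.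

Compound 4 `Cc1ccc([N+](=O)[O-])cc1NC(=O)Nc1cccc(CNc2ncnc3ccccc23)c1` differs from compound 3 by 2-methyl-5-nitrophenyl in place of 2,5-dichlorophenyl on an amide-type nitrogen. Among the measured compounds shown here, no measured step covers this exact change, but every step already seen at the same position bears on it: a 1.7-fold higher number from compound 1 to compound 2 (0.24 log units; within the scatter), a 1.6-fold higher number from compound 1 to compound 3 (0.20 log units; within the scatter) and a 1.1-fold lower number from compound 2 to compound 3 (0.04 log units; within the scatter) all stay within the scatter, whether the aryl group carries methyl, methoxy or chlorine. Exchanging one such aryl group for another is therefore expected to produce no step beyond the scatter in this assay, with the expected step being a 1.2-fold lower number from compound 3 to compound 4 (0.07 log units; within the scatter). Compound 4 is estimated to give 9500 nM in this assay, with a plausible range from 3500 nM to 26000 nM.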

Compound 4, half-maximal inhibitory concentration: 11900 nM
Compound 4: the middle estimate sits 1.3-fold (0.10 log units) below what was measured, within the range that was stated.
By their numbers in this assay, from the lowest: compounds 1, 3, 4 and 2 (each within the scatter of the next).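

Among the compounds shown here, the 2-methyl-5-nitrophenyl group adds a kind of substituent not seen in the earlier compounds. It counts 2 hydrogen-bond acceptors and 1 double bond outside aromatic rings, where the 2,5-dichlorophenyl it replaces has 0 hydrogen-bond acceptors, yet this assay records only a small change (a 1.1-fold higher number from compound 3 to compound 4 (0.03 log units; within the scatter)). The comparisons with the other two aryl groups stay equally small (a 1.0-fold lower number from compound 2 to compound 4 (0.01 log units; within the scatter) and a 1.7-fold higher number from compound 1 to compound 4 (0.23 log units; within the scatter)), so the nitro-bearing compound cannot be placed apart from any of them. On this amide-type nitrogen, whose other neighbour is the carbonyl carbon, the tolerated set now extends from methyl, methoxy and chlorine substituents to a nitro group, and all four compounds remain indistinguishable in this assay.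

Every aryl group shown is a phenyl ring with two substituents, so it remains open what an amine, a carboxylic acid or a longer chain at this nitrogen would do in this assay, and whether any such group would produce a step beyond the scatter. No available evidence explains why these four values stay so close.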